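Aryl swap on the shared core: compound 1 toward compound 4

The compounds below may be only part of what the source reports. "The series", "measured", "known", "first", "only" and "open" are said of these compounds alone.

Measured compounds:
compound 1 `COc1cc(/C=N/Nc2nc(-c3ccc(C(F)(F)F)cc3)cs2)c(Br)c(Br)c1OC` — a functional assay on U-87MG ATCC cells for inhibition, with U-87 MG (Homo sapiens) as the target, read by MTT assay, with a stated time of 48 h; a higher number here means a weaker inhibitor, a lower number a stronger inhibitor: > 100000 nM
compound 2 `Fc1ccc(/C=N/Nc2nc(-c3ccc(F)c(F)c3)cs2)cc1F` — this assay: 43900 nM
compound 3 `COc1ccccc1-c1csc(N/N=C/c2ccc(F)c(F)c2)n1` — this assay: 40600 nM

Compound 1 stands at the edge of the numbers shown: its value in this assay is a limit, not a number, as noted in the limit of > 100000 nM in this assay, at which 1 of the 3 values shown sits. Compounds 2 and 3 sit well inside the measured range. For the measured compounds named here, the step of a 1.1-fold lower number from compound 2 to compound 3 (0.03 log units; within the scatter) is the only measured change of the aryl group on the shared core, and it stayed within the scatter.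

Compound 4 `COc1cc(/C=N/Nc2nc(-c3cccc(Br)c3)cs2)c(Br)c(Br)c1OC` differs from compound 1 in one place: 3-bromophenyl in place of 4-(trifluoromethyl)phenyl on an aromatic carbon. This is again an aryl swap at the same part of the shared core, so the step from compound 2 to compound 3 is the one that bears on it. That step was small, so no movement beyond the scatter is expected for compound 4, with the added uncertainty that compound 1 itself gives only a limit.

Compound 4 is therefore estimated at 100000 nM, in a range from 30000 nM to 300000 nM. The step this estimate implies, a number no higher from compound 1 to compound 4 (the limit leaves the size open), is expected to stay within the scatter, with a real chance that this assay again reports only a limit.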

Compound 4, half-maximal inhibitory concentration: 27600 nM
The estimate for compound 4 lay 3.6-fold (0.56 log units) above the measured number; measured number outside the range, below it.
By their numbers in this assay, from the lowest: compounds 4, 3 and 2 (each within the scatter of the next). At a limit, above all of these: compound 1.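

For the compounds shown here, this position on the shared core does respond to an aryl swap: with 3-bromophenyl in place of 4-(trifluoromethyl)phenyl, this assay records an at least 3.6-fold lower number from compound 1 to compound 4 (0.55 log units; beyond the scatter), beyond the scatter, whereas the only earlier swap at this position, a 1.1-fold lower number from compound 2 to compound 3 (0.03 log units; within the scatter), stayed within it. Compound 1 gives > 100000 nM, which is a limit and not a number. The step therefore has a lower bound but no known size, because one of its ends rests on that limit: the limit of > 100000 nM in this assay, at which 1 of the 4 values shown sits.

Going by these compounds, it remains open whether the step follows from the arrival of 3-bromophenyl or the departure of 4-(trifluoromethyl)phenyl, and a 4-bromophenyl or 3-(trifluoromethyl)phenyl partner on the core of compound 1 would be needed to separate the identity of the group from its place on the ring. Also open, on these data alone, is how an amine or a carboxylic acid on this aryl group would read in this assay.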